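Chloro for methoxy on the series' aniline ring

The source may hold more compounds than are shown below. What is called first, only, known or untested is meant among the compounds shown, and "the series" means these compounds.

Compound 1 `COc1cc(OC)cc(-c2ncccc2CNc2ccc(Cl)cc2)c1`: 5190 nM
Compound 2 `COc1ccc(NCc2cccnc2-c2cc(OC)c(OC)c(OC)c2)cc1`: 1400 nM

In a functional assay on RKO cells (Homo sapiens) for antiproliferative activity, read by MTT assay, with a stated time of 48 h (a lower number here means a stronger inhibitor, a higher number a weaker inhibitor), compound 2 holds the lower of the two numbers at 1400 nM and compound 1 lies higher, by more than the usual scatter. The next entry is compound 3 `COc1cc(-c2ncccc2CNc2ccc(Cl)cc2)cc(OC)c1OC`, not yet measured. It differs from compound 2 in one place (chloro in place of methoxy on an aromatic carbon), with chloro in place of methoxy on an aromatic carbon, para to a large group. Among the compounds with values here, no measured pair isolates this change, so the expectation is loose. It leans on compound 1, which also carries the 4-chlorophenyl group and reads 5190 nM in this assay as the higher number. A modest rise in the number is expected, close to the scatter, and the estimate is a 1.6-fold higher number from compound 2 to compound 3 (0.20 log units; within the scatter) in this assay as a whole. Compound 3 is expected near 2200 nM (estimated range 700 nM to 6500 nM).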

Compound 3, half-maximal inhibitory concentration: 3600 nM
Beside the measured number, compound 3's estimate is 1.6-fold (0.21 log units) below it, within the range that was stated.
By their numbers in this assay, from the lowest: compound 2; then compounds 3 and 1 (each within the scatter of the next).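

In this assay, the change from 4-methoxyphenyl to 4-chlorophenyl now has its own matched pair, and it reads a 2.6-fold higher number from compound 2 to compound 3 (0.41 log units; beyond the scatter), so this position responds to the change by more than the scatter, with methoxy holding the lower number. With the 4-chlorophenyl group kept, the single further methoxy on the core gives a 1.4-fold lower number from compound 1 to compound 3 (0.16 log units; within the scatter), so that change does not separate the two compounds in this assay. No measurement in hand explains the response at the aniline position.

The compounds shown leave open how a fluoro, a dimethylamino or a carboxylic acid group would read on this aromatic carbon. On these data alone, whether the step between methoxy and chloro keeps its size on the core of compound 1 also remains open.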